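This account rests on a few compounds, and the source may have more. Where it says the series, first, only, none or still open, it means among the compounds named here.

Of the compounds shown here, three share one core and have been measured in an assay on HEK293 cells for displacement of a labelled ligand from prostaglandin D2 receptor 2 (Homo sapiens); on this read-out lower numbers stand for stronger inhibition and higher numbers for weaker inhibition. Compound 1 `CCCCCCSc1nc2ccccc2n1CC(=O)O` gives 1360 nM. Compound 2 `CCOC(=O)CCCCSc1nc2ccccc2n1CC(=O)O` gives 2360 nM, and compound 3 `COc1ccccc1CSc1nc2ccccc2n1CC(=O)O` gives 1100 nM. On these numbers compound 1 stands second highest of the three; its nearest neighbour is compound 3, whose number is lower, and its furthest is compound 2, whose number is higher, yet both gaps lie within the scatter, so the three compounds cannot be told apart.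

Within the data shown here, the only step between two compounds that differ in one place is a 1.7-fold higher number from compound 1 to compound 2 (0.24 log units; within the scatter), which is within the scatter.

Compound 4 `O=C(O)Cn1c(SCc2ccc(Br)cc2)nc2ccccc21` has not been measured. It differs from compound 1 by 4-bromophenyl in place of pentyl on a saturated chain carbon bound to a sulfur. Among the measured compounds shown here, no measured step bears directly on this change. The closest hint comes from compound 3, which also carries an aromatic ring on the saturated chain carbon bound to a sulfur, and the gap between compound 1 and compound 3 is within the scatter. The expected step in this assay from compound 1 to compound 4 is therefore small, close to none beyond the scatter, a 1.4-fold lower number from compound 1 to compound 4 (0.13 log units; within the scatter). Compound 4 is estimated to give 1000 nM in this assay, between 400 nM and 2500 nM.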

Compound 4, half-maximal inhibitory concentration: 220 nM
Beside the measured number, compound 4's estimate is 4.5-fold (0.66 log units) above it; the measured number lies below the stated range.
By their numbers in this assay, from the lowest: compound 4; then compounds 3, 1 and 2 (each within the scatter of the next, the first and the last beyond it).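

In this assay, among these compounds, 4-bromophenyl in place of pentyl on the saturated chain carbon bound to a sulfur gives a 6.2-fold lower number from compound 1 to compound 4 (0.79 log units; beyond the scatter), the first step that lies beyond the scatter, so this position can respond to what it carries, which compounds 1, 2 and 3 gave no sign of. Among the compounds shown here, an aromatic ring on this carbon is not enough on its own to produce a lower number: compound 3, the one compound that goes against such a reading, also carries an aromatic ring there, yet gives 1100 nM, within the scatter of compound 1. The data shown offer nothing that accounts for the size of the step.

Going by these compounds, what remains open is how much of the step belongs to the bromine and how much to the ring, a question that a plain phenyl, 4-chlorophenyl or 4-methylphenyl on the same carbon would bear on. On these data alone, all four compounds also keep the same carboxylic acid, so it is still unknown how an ester or an amide in its place would read on this scaffold.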